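The compounds below may be only part of what the source reports. "The series", "measured", "known", "first", "only" and "open" are said of these compounds alone.

Measured compounds in a functional assay on KM12 cells (Homo sapiens) for inhibition, read by sulforhodamine B assay, with a stated time of 48 h; a lower number here means that less compound is tolerated, a higher number that more compound is tolerated:
compound 1, `O=C(Nc1cccc(-n2cc(-c3ccncc3)c(-c3ccc(Cl)c(O)c3)n2)c1)Nc1ccc(Cl)c(Cl)c1`: 26300 nM
compound 2, `COc1cc(-c2nn(-c3cccc(NC(=O)c4ccc(Cl)c(C(F)(F)F)c4)c3)cc2-c2ccncc2)ccc1Cl`: limit only, > 32500 nM
compound 3, `O=C(Nc1cccc(-n2cc(-c3ccncc3)c(-c3ccc(Cl)c(O)c3)n2)c1)Nc1cc(C(F)(F)F)cc(C(F)(F)F)c1`: 4060 nM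

Compound 2 stands apart from the other two in that this assay returned no number for it. The entry > 32500 nM for compound 2 is a limit of the assay, not a measured concentration. Of the three values, compound 2 is the one sitting at the limit of > 32500 nM in this assay, at which 1 of the 3 values shown sits. Compound 1 and compound 3 both give numbers; compound 3 gives 4060 nM and compound 1 gives 26300 nM.

Compound 4, `COc1cc(-c2nn(-c3cccc(NC(=O)Nc4cccc(C(F)(F)F)c4)c3)cc2-c2ccncc2)ccc1Cl`, is not yet measured. It is obtained from compound 2 by (3-(trifluoromethyl)phenyl)amino in place of 4-chloro-3-(trifluoromethyl)phenyl on a carbonyl carbon. Within the data shown here, no step between measured compounds that differ in one place is available, so the size of the change from compound 2 to compound 4 in this assay rests on expectation alone. The expected step of an at least 2.1-fold lower number from compound 2 to compound 4 (0.33 log units; beyond the scatter) is downward, into the range where numbers are obtained, because compound 1 gives 26300 nM and compound 3 gives 4060 nM in this assay. Compound 4 is estimated at 15000 nM, with a range from 4000 nM to 40000 nM, and a fair chance remains that the assay again reports only a limit.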

Compound 4, concentration lethal to 50% of the cells: > 50000 nM
Compound 4 was reported as a limit (the forecaster's own chance of this, stated with the estimate: 30%); at least 3.3-fold (0.52 log units) between middle value and limit.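

In this assay compound 2 gives > 32500 nM, a limit and not a number. Compound 4 gives > 50000 nM, also a limit. Among these compounds, no step from compound 2 to compound 4 can be read. The compounds shown leave open what (3-(trifluoromethyl)phenyl)amino in place of 4-chloro-3-(trifluoromethyl)phenyl on a carbonyl carbon does to the lethal concentration.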